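From a Vinyl to an Ethynyl Tail on a Triol Chain

A few compounds are considered here, and "the series" means these few. Any claim that something is new, unique, unknown or untested is made for them only; others in the source may bear on it.

In a functional assay on A549 cells (Homo sapiens) for cytotoxicity, read by MTT assay (on this read-out higher numbers stand for weaker inhibition and lower numbers for stronger inhibition), compound 1 `CCCCCCCCCCCCCCCC(O)CC(O)CO` gives 3 ug/mL. Compound 2 `C=CCCCCCCCCCCCC(O)CC(O)CO`, tested in the same this assay, gives 3.4 ug/mL. Among the compounds with values here, compound 2 holds the higher of the two numbers, but its only neighbour is compound 1, and the step of a 1.1-fold higher number from compound 1 to compound 2 (0.05 log units; within the scatter) lies within the scatter, so the two compounds cannot be told apart on this read-out.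

Compound 3 `C#CCCCCCCCCCCCC(O)CC(O)CO` has not yet been measured in this assay. It differs from compound 2 in one place: ethynyl in place of vinyl on a saturated chain carbon, ten or more bonds along the chain from an oxygen on a saturated carbon. Within the data shown here, the only measured step that touches the same spot is a 1.1-fold higher number from compound 1 to compound 2 (0.05 log units; within the scatter), the replacement of butyl by vinyl, and it moved the number by less than the scatter. Exchanging the vinyl for an ethynyl on a saturated chain carbon is a change of similar scale at the same place, so no step beyond the scatter is expected in either direction. Compound 3 is therefore expected to give about 3.5 ug/mL, with a likely range from 1.7 ug/mL to 7 ug/mL. This estimate corresponds to an expected step of a 1.0-fold higher number from compound 2 to compound 3 (0.01 log units; within the scatter).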

Compound 3, half-maximal inhibitory concentration: 4.8 ug/mL
Estimate against measurement, compound 3: 1.4-fold (0.14 log units) below; the range from low to high includes it.
By their numbers in this assay, from the lowest: compounds 1, 2 and 3 (each within the scatter of the next).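

Three tail ends can now be compared at this place, butyl, vinyl and ethynyl, and in this assay the two new steps, a 1.4-fold higher number from compound 2 to compound 3 (0.15 log units; within the scatter) and a 1.6-fold higher number from compound 1 to compound 3 (0.20 log units; within the scatter), both stay inside the usual spread of repeated measurements. Replacing the double bond of the vinyl with the triple bond of the ethynyl, with the count of two heavy atoms unchanged, therefore gives no difference that can be told apart at this place on a saturated chain carbon, and the pair furthest apart in number is no exception. Nothing measured here offers an explanation for these numbers.

Going by these compounds, all three tail ends are built only from carbon and hydrogen, so it remains open what an amine, a carboxylic acid or a longer chain would do at this place. On these data alone, it also remains open whether the three compounds would stay this close together on cells other than those used here.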